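The source may report more compounds than this note shows. Statements on the series, on what has been measured and on what is new or still open speak of the compounds shown alone.

Compound 3, `CC[C@H](C)[C@H](NC(=O)CN(c1ncnc2c1ncn2C1CCCCO1)C1CC1)C(=O)OCc1ccccc1`, is the member of the series with the benzyl ester bearing the sec-butyl group. Among the compounds with values here, in a functional assay on the whole organism (Tail, strain ICR) with Mus musculus as the target, in the tail flick test, with a stated time of 60 min, at a dose of 25 umol/kg by the oral route (a lower number here means a weaker effect, a higher number a stronger effect of the compound at the dose given), compound 3 gives 27.4%, the lowest of the three numbers so far. Compound 1, `O=C(O)[C@@H]1CCCN1C(=O)CN(c1nc(Cl)nc2[nH]cnc12)C1CC1`, gives 34.9%, which lies within the scatter of compound 3. Within the data shown here, compound 2, `O=C(CN(c1ncnc2c1ncn2C1CCCCO1)C1CC1)N[C@@H](CO)C(=O)OCc1ccccc1`, gives 46.7% and sits furthest from compound 3; the one step measured at this position, a number 19.3 percentage points lower from compound 2 to compound 3 (beyond the scatter), is a modest loss beyond the scatter when hydroxymethyl is replaced by sec-butyl.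

Compound 4, `NC(=O)C[C@H](NC(=O)CN(c1ncnc2c1ncn2C1CCCCO1)C1CC1)C(=O)OCc1ccccc1`, differs from compound 3 in one place: carbamoylmethyl in place of sec-butyl on a saturated chain carbon bound to an amide-type nitrogen and a carbonyl carbon. This is the same position the measured step touched. That step, going from a group counted with one hydrogen-bond donor and one acceptor to one with none, was a modest loss beyond the scatter; compound 4 goes back to a group counted with one donor and one acceptor. Among the measured compounds shown here, with only that single step as a guide, a rise of comparable size in this assay is expected, though a step within the scatter cannot be ruled out, and a step of a number 14.6 percentage points higher from compound 3 to compound 4 (beyond the scatter) is estimated.

For compound 4 an activity of 42% is therefore expected, with a range from 28% to 56%.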

Compound 4, a percentage reported as activity, at one dose (the size of the read-out at that dose, not a potency): 30.5%
For compound 4 the middle estimate is 11.5 percentage points above the measured one, within the range that was stated.
By their numbers in this assay, from the lowest: compounds 3, 4 and 1 (each within the scatter of the next); then compound 2.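

In this assay the change reads a number 3.1 percentage points higher from compound 3 to compound 4 (within the scatter) and so shows that, at this saturated chain carbon bound to an amide-type nitrogen and a carbonyl carbon, carbamoylmethyl does not separate from sec-butyl, even though it brings a hydrogen-bond donor and a hydrogen-bond acceptor that sec-butyl lacks. Within the data shown here, the donor and acceptor counts alone therefore do not follow the numbers at this position: carbamoyl in place of hydroxy gives a number 16.2 percentage points lower from compound 2 to compound 4 (beyond the scatter) and leaves hydroxymethyl in compound 2 as the only one of the three groups that stands apart, while compound 4 goes against any reading based on the counts. Nothing available bears on why two groups with the same counts give different numbers here.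

As far as these compounds go, whether the number of compound 2 belongs to the hydroxy group itself remains open, and a longer chain ending in hydroxy, such as 2-hydroxyethyl, or a plain methyl at the same carbon would test this. From the compounds shown here alone, how an aminomethyl group or a carboxylic acid such as carboxymethyl at this carbon would compare with hydroxymethyl also remains open.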